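Pyrazin-2-yl Replaces Pyridin-3-yl on the Amine Nitrogen

The source may report more compounds than this note shows. Statements on the series, on what has been measured and on what is new or still open speak of the compounds shown alone.

Within the data shown here, compound 2 `N#Cc1cccc(-c2nc(Nc3cccnc3)sc2-n2ccnc2)c1` holds the lowest of the two numbers so far in an assay on CHO cells for displacement of a labelled ligand from adenosine receptor A1 (Homo sapiens); a lower number here means a stronger inhibitor, a higher number a weaker inhibitor: compound 2 gives 560 nM, while compound 1 `N#Cc1cccc(-c2nc(Nc3cccnc3)sc2-n2cncn2)c1` gives 1530 nM. Among the measured compounds shown here, the only measured step, a 2.7-fold lower number from compound 1 to compound 2 (0.44 log units; beyond the scatter), concerns a different place, where 1H-imidazol-1-yl replaces 1H-1,2,4-triazol-1-yl. Compound 3 `N#Cc1cccc(-c2nc(Nc3cnccn3)sc2-n2ccnc2)c1` carries the change (pyrazin-2-yl in place of pyridin-3-yl on a nitrogen on an aromatic ring). For the measured compounds named here, no measured step bears on this exchange, so no movement beyond the scatter is expected for compound 3, whose estimate is 600 nM with a range from 200 nM to 1800 nM. The expected step is therefore a 1.1-fold higher number from compound 2 to compound 3 (0.03 log units; within the scatter).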

Compound 3, inhibition constant: 46 nM
Compound 3: the middle estimate sits 13-fold (1.12 log units) above what was measured, outside the stated range (below it).
By their numbers in this assay, from the lowest: compound 3; then compound 2; then compound 1.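

Exchanging pyridin-3-yl for pyrazin-2-yl on the amine nitrogen brings a 12-fold lower number from compound 2 to compound 3 (1.09 log units; beyond the scatter) in this assay, so this position, untouched by the earlier step, responds strongly. Both groups have the same count of heavy atoms, and the entering ring differs by one further ring nitrogen in place of a carbon. Nothing available explains the size of this step. The compounds shown leave open whether the same exchange would carry over with 1H-1,2,4-triazol-1-yl in place of 1H-imidazol-1-yl. They also leave open how a phenyl or pyrimidin-2-yl group would read on that nitrogen.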